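The source may report more compounds than this note shows. Statements on the series, on what has been measured and on what is new or still open speak of the compounds shown alone.

Compound 3 `C=C(Br)C(=O)Nc1cccc(/C=C/C(=O)Nc2cc(OC)c(OC)c(OC)c2)c1` gives 2300 nM in a functional assay on HT-29 cells (Homo sapiens) for inhibition, read by MTT assay, with a stated time of 72 h (a lower number here means a stronger inhibitor, a higher number a weaker inhibitor), level within the scatter with compound 2 `COc1cc(NC(=O)/C=C/c2cccc(OCc3ccccc3)c2)cc(OC)c1OC` at 3600 nM, and well under compound 1 `COc1cccc(/C=C/C(=O)Nc2cc(OC)c(OC)c(OC)c2)c1` at 44100 nM. Compound 4 `COc1cc(NC(=O)/C=C/c2cccc(N)c2)cc(OC)c1OC` differs from compound 3 by hydrogen in place of (1-bromoethenyl)carbonyl on a nitrogen on an aromatic ring. Going by the values given here, no measured step tests amino directly. The nearest evidence is a 19-fold lower number from compound 1 to compound 3 (1.28 log units; beyond the scatter), on ((1-bromoethenyl)carbonyl)amino replacing methoxy, and a 12-fold lower number from compound 1 to compound 2 (1.09 log units; beyond the scatter), on the change to benzyloxy. Both are large, so losing the (1-bromoethenyl)carbonyl should move the number back toward that of compound 1. The expected change in this assay is an 11-fold higher number from compound 3 to compound 4 (1.04 log units; beyond the scatter), a large rise. For compound 4 the estimated value is 25000 nM, within a range of 8000 nM to 70000 nM.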

Compound 4, half-maximal inhibitory concentration: 63100 nM
For compound 4 the middle estimate is 2.5-fold (0.40 log units) below the measured one, within the range that was stated.
By their numbers in this assay, from the lowest: compounds 3 and 2 (each within the scatter of the next); then compounds 1 and 4 (each within the scatter of the next).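

In this assay, stripping the acyl group to leave a bare amino gives a 27-fold higher number from compound 3 to compound 4 (1.44 log units; beyond the scatter), and amino in place of benzyloxy gives an 18-fold higher number from compound 2 to compound 4 (1.24 log units; beyond the scatter). Amino and methoxy on this aromatic carbon are level (a 1.4-fold higher number from compound 1 to compound 4 (0.16 log units; within the scatter)), so the lower numbers of compound 2 and compound 3 go with those larger groups, not with replacing methoxy as such. As far as these compounds go, whether an acetyl group on that nitrogen, lacking the bromine, would keep the lower number remains open, as does the effect of a carboxylic acid here. No measurement shown gives a cause for these steps.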